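The source may hold more compounds than are shown below. What is called first, only, known or untested is meant among the compounds shown, and "the series" means these compounds.

Working notes on the series, read in a functional assay on A549 cells (Homo sapiens) for antiproliferative activity, read by MTT assay; a lower number here means a stronger inhibitor, a higher number a weaker inhibitor. Compound 1 `O=C1NC(c2ccccc2)CN1S(=O)(=O)c1ccc2c(c1)CCCN2` gives > 20000 nM, which is a limit of the assay. Compound 2 `O=C(OCCCl)N1CCCc2cc(S(=O)(=O)N3CC(c4ccccc4)NC3=O)ccc21` gives > 20000 nM, which is also a limit. For compound 3 `O=C(CCl)N1CCCc2cc(S(=O)(=O)N3CC(c4ccccc4)NC3=O)ccc21` the entry reads "not determined" (no result reported), so compound 3 has no single number. Among the compounds with values here, the only values standing around it are these two limits.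

The change to compound 4 `NC(=O)N1CCCc2cc(S(=O)(=O)N3CC(c4ccccc4)NC3=O)ccc21` is amino in place of chloromethyl on a carbonyl carbon, or, cut one bond further out, (chloromethyl)carbonyl to carbamoyl. Within the data shown here, the one measured step that bears on it is a step that the two limits leave unreadable from compound 1 to compound 2, with (2-chloroethoxy)carbonyl in place of hydrogen on a nitrogen on an aromatic ring in a ring. Both of its ends are limits, so it offers no size to carry over. Among the measured compounds shown here, with no number for compound 3 either, no step of any particular size or direction can be expected in this assay. Compound 4 is expected to stay in the region of that limit because of the limit of > 20000 nM in this assay, at which 2 of the 3 values shown sit, and a further limit is a likely report. Compound 4 is estimated at 15000 nM, with an expected range of 3000 nM to 40000 nM.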

Compound 4, half-maximal inhibitory concentration: 2540 nM
The estimate for compound 4 lay 5.9-fold (0.77 log units) above the measured number; measured number below the stated range.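

In this assay, carbamoyl in place of hydrogen on a nitrogen on an aromatic ring in a ring gives an at least 7.8-fold lower number from compound 1 to compound 4 (0.89 log units; beyond the scatter), and amino in place of 2-chloroethoxy on a carbonyl carbon gives an at least 7.8-fold lower number from compound 2 to compound 4 (0.89 log units; beyond the scatter). A carbonyl on that nitrogen is not enough on its own to bring a number, since compound 2 carries one too and gives > 20000 nM, which is a limit of the assay. Steps between the two limits or involving compound 3 cannot be read, and among the values shown compound 4 alone stands clear of the limit: the limit of > 20000 nM in this assay, at which 2 of the 4 values shown sit.

From the compounds shown here alone, the full size of both new steps stays open, since each starts from a limit, and the chloromethyl of compound 3 has no number to set against the amino of compound 4. Also open, going by these compounds, is whether methylamino, dimethylamino or a plain methyl on that carbonyl carbon would keep, improve or lose the number of compound 4.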